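From Aryl Ester to Benzyl Carbamate at the Carbonyl

The compounds below may be only part of what the source reports. "The series", "measured", "known", "first", "only" and "open" are said of these compounds alone.

Of the compounds shown here, two carry numbers so far. Compound 1 `COc1cccc(C(=O)OC(CCN(C)C)c2ccc(Cl)cc2)c1C` and compound 2 `Cc1c(Cl)cccc1C(=O)OC(CCN(C)C)c1ccc(Cl)cc1` share the same core and differ only in one group on the aromatic ring attached to the carbonyl. In an assay on NIH3T3 cells with Urotensin-2 receptor (Homo sapiens) as the target (a higher number here means a larger maximal response, a lower number a smaller maximal response), compound 1 gives 88%, while compound 2 gives 118%. Going by the values given here, the single measured step is a number 30 percentage points higher from compound 1 to compound 2 (beyond the scatter). Among the compounds with values here, compound 2 thus stands highest of the two numbers, with compound 1 its only neighbour, separated by that step.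

Compound 3 `CN(C)CCC(OC(=O)NCc1ccccc1)c1ccc(Cl)cc1` has not yet been measured. The change from compound 2 is benzylamino in place of 3-chloro-2-methylphenyl on a carbonyl carbon. Within the data shown here, the one step known so far concerned a substituent on the very ring that now leaves as a whole, so it speaks only loosely to this exchange; no measured pair tests an amine in place of an aryl group at the carbonyl. Since the ring whose substitution raised the response is removed entirely, a decrease beyond the scatter in this assay seems more likely than a rise, but the size is uncertain. Compound 3 is expected to give about 80%, within 40% to 120%. That expectation amounts to an estimated step of a number 38 percentage points lower from compound 2 to compound 3 (beyond the scatter).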

Compound 3, largest response reached (reported as efficacy), in percent of the reference or control that the assay uses: 180%
Compound 3: the middle estimate sits 100 percentage points below what was measured; measured number outside the range, above it.
By their numbers in this assay, from the lowest: compound 1; then compound 2; then compound 3.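

Going by these compounds alone, at the carbonyl carbon, benzylamino in place of 3-chloro-2-methylphenyl gives a number 62 percentage points higher from compound 2 to compound 3 (beyond the scatter) in this assay, a large step, whereas the only earlier step, a number 30 percentage points higher from compound 1 to compound 2 (beyond the scatter), was modest and came from a change on the ring itself. This shows that the response at this position does not depend on keeping the substituted aryl ring, since compound 3, which carries neither its chloro nor its methyl group, gives 180%. The two groups have the same number of heavy atoms and each holds one six-membered aromatic ring, but the entering group brings nitrogen and a hydrogen-bond donor, and no available evidence explains why the response rises.

Because this single exchange alters several features at once, the compounds shown do not separate the contribution of the amide hydrogen from that of the carbon linking the ring or from the loss of the ring's chloro and methyl groups. On these data alone, it also remains open how this assay would respond to an N-methylbenzylamino group, to the longer chain of phenethylamino, or to a chlorobenzylamino group at this carbonyl carbon.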